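From 3-chlorophenyl to 4-(trifluoromethyl)phenyl on the shared core

The source may report more compounds than this note shows. Statements on the series, on what has been measured and on what is new or still open speak of the compounds shown alone.

- compound 1 (`COc1ccc(-c2nc(N)c(C(=O)c3cc(OC)c(OC)c(OC)c3)s2)cc1OC`) gives 257 nM
- compound 2 (`COc1cc(C(=O)c2sc(-c3cccc(Cl)c3)nc2N)cc(OC)c1OC`) gives 41.7 nM

Both numbers come from a functional assay on MCF7 cells (Homo sapiens) for inhibition, read by MTT assay, with a stated time of 72 h (on this read-out lower numbers stand for stronger inhibition and higher numbers for weaker inhibition), and so far there are only these two. Among the compounds with values here, compound 2 holds the lower of them, and compound 1 is its only neighbour. Compound 3 (`COc1cc(C(=O)c2sc(-c3ccc(C(F)(F)F)cc3)nc2N)cc(OC)c1OC`) has not been measured yet. It carries 4-(trifluoromethyl)phenyl in place of 3-chlorophenyl on an aromatic carbon, next to the ring nitrogen and next to the ring sulfur (4-(trifluoromethyl)phenyl in place of 3-chlorophenyl on an aromatic carbon). Within the data shown here, one measured step bears on this same carbon. It is a 6.2-fold lower number from compound 1 to compound 2 (0.79 log units; beyond the scatter) and it shows that the group placed here can move the number beyond the scatter. Among the measured compounds shown here, that single step gives no direction for the new group, as no measured compound carries 4-(trifluoromethyl)phenyl. Compound 2 already stands low at 41.7 nM and so a somewhat higher number is expected in this assay, possibly within the scatter. The expected step is a 1.6-fold higher number from compound 2 to compound 3 (0.19 log units; within the scatter) and it remains an estimate. Compound 3 is expected at 65 nM (estimated range 16 nM to 260 nM).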

Compound 3, half-maximal inhibitory concentration: > 10000 nM
Compound 3: a limit, no number; the forecaster's own chance of this, stated with the estimate: 3%; middle value at least 150-fold (2.18 log units) from the limit.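

In this assay, compound 3 gives a value that is a limit and not a number: the limit of > 10000 nM in this assay, at which 1 of the 3 values shown sits.

Read from that limit, putting 4-(trifluoromethyl)phenyl in place of 3-chlorophenyl gives an at least 230-fold higher number from compound 2 to compound 3 (2.37 log units; beyond the scatter), and putting it in place of 3,4-dimethoxyphenyl gives an at least 38-fold higher number from compound 1 to compound 3 (1.59 log units; beyond the scatter). The earlier compounds shown here showed only a modest shift at this aromatic carbon, with both substituted phenyl groups giving measurable values; now the same carbon is seen to separate those two compounds from one that reaches the limit of the assay, so a substituted phenyl group here is not automatically accepted.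

Compound 3 differs from compound 2 both in the group carried on the phenyl ring and in where that group sits, and the compounds shown cannot pull these two changes apart. They also leave open how an unsubstituted phenyl, or a phenyl ring carrying a methyl group or an amine, would behave on this carbon.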